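The source may hold more compounds than are shown below. What is called first, only, known or untested is meant among the compounds shown, and "the series" means these compounds.

Going by the values given here, compound 1 `O=C(OCc1ccccc1)N1CCN(C(=S)SCc2cn(Cc3ccc(Cl)cc3)nn2)CC1` is the weaker of the two compounds measured so far: in a functional assay on MGC-803 cells (Homo sapiens) for inhibition, read by MTT assay, with a stated time of 72 h (on this read-out higher numbers stand for weaker inhibition and lower numbers for stronger inhibition), compound 1 gives 31300 nM, the highest of the two numbers. Its nearest neighbour, compound 2 `O=C(OCc1ccccc1)N1CCN(C(=S)SCc2cn(Cc3ccc(Cl)c(Cl)c3)nn2)CC1`, carries an extra chloro in place of hydrogen on an aromatic carbon, and in this assay compound 2 gives 7140 nM; the step is a 4.4-fold lower number from compound 1 to compound 2 (0.64 log units; beyond the scatter). Compound 3 `CC(C)(C)OC(=O)N1CCN(C(=S)SCc2cn(Cc3ccc(Cl)cc3)nn2)CC1` leaves the aromatic ring of compound 1 untouched and changes the far end of the molecule instead: tert-butyl in place of benzyl on an oxygen next to a carbonyl group. Among the compounds with values here, no measured step touches this position. Within the data shown here, the only step recorded, from compound 1 to compound 2, concerns the aromatic ring and offers no guide to an exchange at the oxygen next to the carbonyl group. With nothing to point in either direction, the expectation for compound 3 in this assay is a step of a 1.0-fold lower number from compound 1 to compound 3 (0.02 log units; within the scatter), within the scatter. Compound 3 is therefore estimated at 30000 nM, with a range from 10000 nM to 90000 nM, and the estimate is held loosely.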

Compound 3, half-maximal inhibitory concentration: 9790 nM
For compound 3 the middle estimate is 3.1-fold (0.49 log units) above the measured one; the measured number lies below the stated range.
By their numbers in this assay, from the lowest: compounds 2 and 3 (each within the scatter of the next); then compound 1.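

In this assay the exchange of benzyl for tert-butyl on an oxygen next to a carbonyl group gives a 3.2-fold lower number from compound 1 to compound 3 (0.50 log units; beyond the scatter) and so shows that this end of the molecule, which the earlier pair left untouched, has a bearing on the read-out. The exchange takes away the six-membered aromatic ring of carbon only and replaces a group of 7 heavy atoms with one of 4, yet the number does not rise, so for this pair the benzyl group and its ring are not required for the inhibition seen with compound 1. The data at hand offer no measurement that accounts for this step.

A single pair cannot separate the loss of the aromatic ring from the change in group size or shape, and a small straight chain such as ethyl or a saturated ring such as cyclohexylmethyl on the same oxygen would be needed to pull these apart. From the compounds shown here alone, it also remains open whether the chloro step seen on the aromatic ring would carry over to a compound bearing tert-butoxycarbonyl.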